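Adding phenylsulfonyl to the ring nitrogen of compound 3

The source may report more compounds than this note shows. Statements on the series, on what has been measured and on what is new or still open speak of the compounds shown alone.

- Compound 1 `CN1C/C(=C\c2ccncc2)C(=O)/C(=C/c2ccccc2C(F)(F)F)C1` gives 4100 nM
- Compound 2 `O=C1/C(=C/c2cccnc2)CN(S(=O)(=O)c2ccccc2)C/C1=C\c1ccccc1C(F)(F)F` gives 10900 nM
- Compound 3 `O=C1/C(=C/c2ccncc2)CNC/C1=C\c1ccccc1C(F)(F)F` gives 4500 nM

All three compounds were tested in a functional assay on SMMC-7721 cells (Homo sapiens) for cytotoxicity, read by MTT assay, with a stated time of 24 h; a lower number here means a stronger inhibitor, a higher number a weaker inhibitor. Compound 3 sits level with compound 1, and the measured step is a 1.1-fold higher number from compound 1 to compound 3 (0.04 log units; within the scatter). Compound 2 shows a higher number than compound 3, a gap beyond the scatter, so it is the weaker inhibitor of that pair.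

The next compound is compound 4 `O=C1/C(=C/c2ccncc2)CN(S(=O)(=O)c2ccccc2)C/C1=C\c1ccccc1C(F)(F)F`. It carries phenylsulfonyl in place of hydrogen on an amine nitrogen in a ring. For the measured compounds named here, the one measured step at this nitrogen swaps hydrogen for methyl only, so it says little about a group as large as phenylsulfonyl. Compound 2 is the better guide, since it carries phenylsulfonyl on the same kind of nitrogen and gives 10900 nM. However, compound 2 also differs from compound 4 elsewhere, and no measured pair isolates the group. A move toward weaker inhibition is therefore expected, of about the size of the gap between compound 3 and compound 2. In this assay the expected change is a 2.0-fold higher number from compound 3 to compound 4 (0.30 log units; within the scatter). For compound 4 the estimate is 9000 nM, with an expected range from 4000 nM to 20000 nM.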

Compound 4, half-maximal inhibitory concentration: 6540 nM
Beside the measured number, compound 4's estimate is 1.4-fold (0.14 log units) above it; the measured number falls inside the stated range.
By their numbers in this assay, from the lowest: compounds 1, 3, 4 and 2 (each within the scatter of the next, the first and the last beyond it).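

In this assay, the ring nitrogen now has a pair that isolates phenylsulfonyl, and the step (a 1.5-fold higher number from compound 3 to compound 4 (0.16 log units; within the scatter)) shows that this much larger group gives a number that cannot be told apart from that of hydrogen; the step from methyl (a 1.6-fold higher number from compound 1 to compound 4 (0.20 log units; within the scatter)) reads the same way, so hydrogen, methyl and phenylsulfonyl on this nitrogen all sit within the scatter of the compound carrying phenylsulfonyl. For the compounds shown here, the result also isolates the pyridine change for the first time, and the step (a 1.7-fold lower number from compound 2 to compound 4 (0.22 log units; within the scatter)) shows that moving from pyridin-3-yl to pyridin-4-yl, with phenylsulfonyl on the nitrogen, also stays within the scatter. No measurement here explains why these numbers stay so close.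

The compounds shown leave open whether an acetyl or benzyl group on the ring nitrogen, or a methoxy or chlorine on the phenyl ring of phenylsulfonyl, would keep the number in this range. They also leave open how pyridin-2-yl or a plain phenyl group would compare with pyridin-4-yl on the double-bonded chain carbon.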